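Swapping methoxy for cyano on a shared core

This account rests on a few compounds, and the source may have more. Where it says the series, first, only, none or still open, it means among the compounds named here.

Clearance values in an ADME assay on microsomes from liver (Rattus norvegicus) for metabolic stability; a higher number here means faster removal of the compound, a lower number slower removal
compound 1 `CCCC(C#N)(CCC)Nc1nc(NC)nc(-n2cncn2)n1` gives 32 mL/min/kg
compound 2 `CNc1nc(NC2(C#N)CCCCC2)nc(N(C)C)n1` gives 276 mL/min/kg
compound 3 `CNc1nc(NC2(C#N)CCCCC2)nc(OC)n1` gives 196 mL/min/kg

Compound 3, at 196 mL/min/kg, sits within the scatter of compound 2 at the upper end of these three numbers. Compound 1, at 32 mL/min/kg, lies well beyond the scatter beneath compound 3.

The next compound is compound 4 `CNc1nc(C#N)nc(NC2(C#N)CCCCC2)n1`, still to be measured in this assay. It arises from compound 3 by one change (cyano in place of methoxy on an aromatic carbon), with cyano in place of methoxy on an aromatic carbon, opposite the ring nitrogen.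

Going by the values given here, only one measured step bears on this place. In that step, a 1.4-fold lower number from compound 2 to compound 3 (0.15 log units; within the scatter), one group on the same aromatic carbon gave way to another, and the number stayed within the scatter. Compound 1 differs from compound 3 in more than one place, so it isolates no single change. Among the compounds with values here, no measured compound carries cyano on this carbon, which leaves the expectation loose.

The expected step, a 1.2-fold lower number from compound 3 to compound 4 (0.06 log units; within the scatter), is therefore none beyond the scatter. For compound 4 the estimated clearance is 170 mL/min/kg, with an expected range from 80 mL/min/kg to 330 mL/min/kg.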

Compound 4, clearance: 122 mL/min/kg
Compound 4: middle estimate off by 1.4-fold (0.14 log units), on the high side; low and high end bracket the measured number.
By their numbers in this assay, from the lowest: compound 1; then compounds 4, 3 and 2 (each within the scatter of the next, the first and the last beyond it).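

In this assay, three groups can now be read on this one aromatic carbon of the shared core, the carbon that lies between two ring nitrogen atoms: dimethylamino, methoxy and cyano. The exchange of methoxy for cyano gives a 1.6-fold lower number from compound 3 to compound 4 (0.21 log units; within the scatter) and stays within the scatter, as the exchange of dimethylamino for methoxy did, so neither single exchange separates its pair. Taken across both exchanges, however, the comparison of cyano with dimethylamino gives a 2.3-fold lower number from compound 2 to compound 4 (0.35 log units; beyond the scatter) and is the first on this carbon to pass beyond the scatter, though only modestly. No supporting data bear on the reason for these steps.

The compounds shown leave open whether a carboxylic acid, a primary amine or a longer alkyl chain on this carbon would move the number further from that of compound 3 than cyano does. They also leave open whether cyano would behave the same way with the group of 9 heavy atoms replaced, since compound 1 differs from these compounds in more than one place.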